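Ethoxy in Place of Ethyl on the Acid Core

The compounds below may be only part of what the source reports. "The series", "measured", "known", "first", "only" and "open" are said of these compounds alone.

The measured compounds:
compound 1 `CCc1cccc2cc(C(=O)O)cnc12` — in a functional assay on the whole organism (strain Sprague-Dawley) for inhibition, with Rattus norvegicus as the target (a higher number here means that more compound is needed for the effect, a lower number that less compound is needed), compound 1 gives > 50 mg/kg, a limit of the assay
compound 2 `CCc1cccc2cc(-c3nn[nH]n3)cnc12` — in this assay compound 2 gives 2.5 mg/kg
compound 3 `O=c1c(-c2nn[nH]n2)c[nH]c2c(Cl)cc(Cl)cc12` — in this assay compound 3 gives > 0.156 mg/kg, again a limit of the assay

Compound 1 stands only at a limit in this assay, the limit described by the limit of > 50 mg/kg in this assay, at which 1 of the 3 values shown sits; compound 3 sits at the other limit, described by the limit of > 0.156 mg/kg in this assay, at which 1 of the 3 values shown sits. Among the compounds with values here, the one measured step, an at least 20-fold lower number from compound 1 to compound 2 (1.30 log units; beyond the scatter), concerns 2H-tetrazol-5-yl in place of carboxy on an aromatic carbon and leaves the ethyl group untouched.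

Compound 4 `CCOc1cccc2cc(C(=O)O)cnc12` carries the carboxy group of compound 1 and differs from it in one place: ethoxy in place of ethyl on an aromatic carbon. No measured step among these compounds exchanges ethyl for ethoxy, so nothing here sets a size or a direction for this change. The step is therefore estimated as a number no higher from compound 1 to compound 4 (the limit leaves the size open). Compound 4 is expected to remain near the limit that compound 1 shows, the estimate for compound 4 being 50 mg/kg within 15 mg/kg to 200 mg/kg.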

Compound 4, minimum effective dose: > 25 mg/kg
Compound 4: no number, only a limit; the forecaster's own chance of this, stated with the estimate: 70%; the middle value is on the limit's open side.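

In this assay compound 4 gives > 25 mg/kg, a limit of the assay. Compound 1 also stands only at a limit, so no step can be read between compound 1 and compound 4. The compounds shown leave open what ethoxy in place of ethyl does to the minimum effective dose.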